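The compounds below may be only part of what the source reports. "The series", "measured", "known", "first", "only" and "open" are said of these compounds alone.

Going by the values given here, in an ADME assay on HepG2 2.2.15 cells (Homo sapiens) for cytotoxicity, read by MTT assay, with a stated time of 8 days (on this read-out lower numbers stand for higher toxicity in this test and higher numbers for lower toxicity in this test), compound 2 `CN(C)CCNc1nc(F)c(-c2nn(Cc3ccc(C#N)cc3)c(=O)c3ccccc23)cc1Cl` gives 9760 nM, the only measured number among the three values shown. Compound 1 `N#Cc1ccc(Cn2nc(-c3cc(Cl)c(NC[C@H](O)CO)nc3F)c3ccccc3c2=O)cc1` gives > 100000 nM, which is a limit of the assay. Compound 3 `Cc1nc(-c2ccc(F)nc2F)cn(Cc2ccc(Cl)cc2)c1=O` likewise gives > 100000 nM, a limit. Among the compounds with values here, the single measured step, an at least 10-fold lower number from compound 1 to compound 2 (1.01 log units; beyond the scatter), is read against (the limit of > 100000 nM in this assay, at which 2 of the 3 values shown sit). Compound 4 `COC(=O)CCNc1nc(F)c(-c2nn(Cc3ccc(C#N)cc3)c(=O)c3ccccc23)cc1Cl` differs from compound 2 as methoxycarbonyl in place of dimethylamino on a saturated chain carbon, two bonds along the chain from a nitrogen on an aromatic ring. The step from compound 1 to compound 2 bears on this change only in part: it ran the other way and brought in the dimethylamino that now leaves, so a return toward the region of the limits is the most that can be expected. The change from compound 2 to compound 4 is expected to give a 4.6-fold higher number from compound 2 to compound 4 (0.66 log units; beyond the scatter). Compound 4 is accordingly estimated at 45000 nM, within 12000 nM to 150000 nM.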

Compound 4, half-maximal cytotoxic concentration: > 100000 nM
Compound 4 ended at the assay's limit (the forecaster's own chance of this, stated with the estimate: 45%); middle value at least 2.2-fold (0.34 log units) from the limit.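

In this assay, methoxycarbonyl in place of dimethylamino, on a saturated chain carbon two bonds along the chain from a nitrogen on an aromatic ring, gives an at least 10-fold higher number from compound 2 to compound 4 (1.01 log units; beyond the scatter). Of the three chains shown on this shared core, only the one in compound 2 gives a measured number, and those of compound 1 and compound 4 both end at a limit. The step between compound 1 and compound 4 cannot be read, and the comparison rests on one measured number: the limit of > 100000 nM in this assay, at which 3 of the 4 values shown sit.

On these data alone, whether the measured number belongs to dimethylamino alone or to amines at this place stays open. A primary amine, a pyrrolidine, a carboxylic acid or a longer chain carrying dimethylamino would test this.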